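Swapping the dimethoxyphenyl for phenyl on a tolerant core

This account rests on a few compounds, and the source may have more. Where it says the series, first, only, none or still open, it means among the compounds named here.

Compound 1 `COc1ccc(OC)c(C2C(C(C)=O)=C(C)N(Cc3cn(Cc4ccccc4)nn3)C(=O)N2Cc2cn(Cc3ccccc3)nn2)c1` was tested in an ADME assay on HEL cells (Homo sapiens), read by cell counting, with a stated time of 3 days (a lower number here means that less compound is tolerated, a higher number that more compound is tolerated), and gave no single number. In this assay compound 1 stands at a limit of the assay, > 100000 nM. That entry is the limit of > 100000 nM in this assay, at which 1 of the 2 values shown sits, so the cells tolerated as much compound as was applied. Compound 2 `COc1ccc(OC)c(C2NC(=O)N(Cc3cn(Cc4ccc([N+](=O)[O-])cc4)nn3)C(C)=C2C(C)=O)c1` has in this assay "not determined" (no result reported), so it adds nothing to the numbers. Compound 3 `CC(=O)C1=C(C)N(Cc2cn(Cc3ccccc3)nn2)C(=O)N(Cc2cn(Cc3ccccc3)nn2)C1c1ccccc1` has not yet been measured. It differs from compound 1 in one place: phenyl in place of 2,5-dimethoxyphenyl on a saturated ring carbon. Among the compounds with values here, no step between two measured compounds is available, so the size of this kind of change is unknown from the data. Compound 1 stands at > 100000 nM, and so the change is expected to stay within the scatter: a number no higher from compound 1 to compound 3 (the limit leaves the size open). Compound 3 is therefore expected to give 100000 nM in this assay, between 50000 nM and 200000 nM, most likely again only as a limit.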

Compound 3, half-maximal cytotoxic concentration: 7020 nM
The estimate for compound 3 lay 14-fold (1.15 log units) above the measured number; measured number outside the range, below it.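

In this assay, the change of phenyl in place of 2,5-dimethoxyphenyl on a saturated ring carbon gives an at least 14-fold lower number from compound 1 to compound 3 (1.15 log units; beyond the scatter). Within the data shown here, this shows that the group at this position matters to how much compound the cells tolerate, which compound 1 could not show on its own, with no step to compare it against. The true size of the step remains unknown, since the value for compound 1 is a limit of the assay and not a number: the limit of > 100000 nM in this assay, at which 1 of the 3 values shown sits.

The compounds shown do not tell whether removing both methoxy groups is needed for this step, or whether a phenyl bearing a single methoxy group would behave like compound 1 or like compound 3. They also leave open how a hydroxyl group or a chlorine on this phenyl would read in this assay.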